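The source may hold more compounds than are shown below. What is called first, only, known or untested is meant among the compounds shown, and "the series" means these compounds.

Working notes on compound 1 `O=c1[nH]c(=O)n([C@H]2C[C@H](O)[C@@H](CO)O2)cc1CF`, compound 2 `CC(=O)OC[C@H]1O[C@@H](n2cc(C(F)F)c(=O)[nH]c2=O)C[C@@H]1OC(C)=O` and compound 3 `O=c1[nH]c(=O)n([C@H]2C[C@H](O)[C@@H](CO)O2)cc1C(F)F`. In a functional assay on HL-60 cells (Homo sapiens) for inhibition, with a stated time of 48 h (on this read-out lower numbers stand for stronger inhibition and higher numbers for weaker inhibition), compound 1 gives > 1000 uM, which is a limit and not a number. In this assay, within the data shown here, compound 2 gives 14 uM, the only true number so far. Compound 3 differs from compound 1 by fluoro in place of hydrogen on a saturated chain carbon bound to an aromatic carbon and a fluorine atom, or fluoromethyl to difluoromethyl. No measured step sizes this change. Among the measured compounds shown here, a drop in the read-out of this assay is still expected, well beyond the scatter, and the one number to lean on is compound 2 at 14 uM. The expected move is an at least 25-fold lower number from compound 1 to compound 3 (1.39 log units; beyond the scatter), large but uncertain. For compound 3 the estimate is 40 uM, with an expected range of 5 uM to 300 uM.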

Compound 3, concentration for 50% inhibition: 1.25 uM
Beside the measured number, compound 3's estimate is 32-fold (1.51 log units) above it; measured number below the stated range.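

Among these compounds, the first measured step at this position, fluoromethyl to difluoromethyl on the shared core, gives an at least 800-fold lower number from compound 1 to compound 3 (2.90 log units; beyond the scatter), so fluoro in place of hydrogen on this saturated chain carbon is enough to bring a real number into this assay. In this assay compound 1 gives > 1000 uM, which is a limit and not a number. The step therefore fixes a floor for the effect of this change rather than its true size, because one end of it rests on that limit: the limit of > 1000 uM in this assay, at which 1 of the 3 values shown sits.

From the compounds shown here alone, whether the trend continues to trifluoromethyl at this place, or how a plain methyl or a hydroxymethyl group would read, remains open. Compound 2 differs from compound 3 in more than one place, so the shown values do not isolate the contribution of its acetyl esters.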